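A few compounds are considered here, and "the series" means these few. Any claim that something is new, unique, unknown or untested is made for them only; others in the source may bear on it.

Working notes on the series, read in a physicochemical assay for lipophilicity, at pH 7.4; on this read-out lower numbers stand for lower lipophilicity and higher numbers for higher lipophilicity. Compound 1 `CC(C)CN(c1ccc(F)cc1)S(=O)(=O)c1ccc2c(c1)C(O)CC(C1CCOCC1)O2` gives 3.39, compound 2 `CC(C)CN(c1ccc(C#N)cc1)S(=O)(=O)c1ccc2c(c1)C(O)CC(C1CCOCC1)O2` gives 3.07, and compound 3 `CC(C)CN(Cc1ccccc1C(F)(F)F)S(=O)(=O)c1ccc2c(c1)C(O)CC(C1CCOCC1)O2` gives 4.23, the highest of the three numbers. Next in line is compound 4 `Cc1ccc(N(CC(C)C)S(=O)(=O)c2ccc3c(c2)C(O)CC(C2CCOCC2)O3)c(C)c1`, which differs from the benzyl compound as follows: 2,4-dimethylphenyl in place of 2-(trifluoromethyl)benzyl on a sulfonamide nitrogen. In words, 2,4-dimethylphenyl stands in place of 2-(trifluoromethyl)benzyl on a sulfonamide nitrogen. Two measured steps at this nitrogen bear on the change: a number 0.84 log units higher from compound 1 to compound 3 (beyond the scatter), which is modest, and a number 1.16 log units higher from compound 2 to compound 3 (beyond the scatter), which is large. Both run from a substituted phenyl to the benzyl group, so the change here runs the opposite way. The remaining step, a number 0.32 log units lower from compound 1 to compound 2 (beyond the scatter), shows a smaller shift from changing the phenyl substituent alone. Among the compounds with values here, no measured compound carries methyl groups on that phenyl, so the size of the return is uncertain. A modest fall in this assay is expected, with the estimated step being a number 0.38 log units lower from compound 3 to compound 4 (beyond the scatter). For compound 4 the estimated value is 3.85, with an expected range from 3.45 to 4.25.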

Compound 4, distribution coefficient: 4.19
Compound 4: middle estimate off by 0.34 log units, on the low side; the range from low to high includes it.
By their numbers in this assay, from the lowest: compound 2; then compound 1; then compounds 4 and 3 (each within the scatter of the next).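

In this assay, 2,4-dimethylphenyl and 2-(trifluoromethyl)benzyl on the sulfonamide nitrogen cannot be told apart, with a number 0.04 log units lower from compound 3 to compound 4 (within the scatter). Compound 4 keeps a phenyl directly on this nitrogen and still shows a number 0.80 log units higher from compound 1 to compound 4 (beyond the scatter) and a number 1.12 log units higher from compound 2 to compound 4 (beyond the scatter), so among these compounds a high number does not require the benzyl group, and the ring substituents alone separate compound 4 from compound 1 and compound 2. No supporting data are available to explain this result.

From the compounds shown here alone, it remains open how a phenyl carrying a single methyl would read, which would show whether both methyl groups are needed for the number seen with compound 4. Also open, going by these compounds, is how this assay would respond to an amine or a carboxylic acid on the phenyl ring.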